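The compounds below may be only part of what the source reports. "The series", "measured", "known", "first", "only" and "open" are said of these compounds alone.

Measured in a functional assay on Caco-2 cells (Homo sapiens) for cytotoxicity, read by MTT assay, with a stated time of 4 h; on this read-out higher numbers stand for weaker inhibition and lower numbers for stronger inhibition:
- compound 1 `COC(=O)C1=CO[C@@H](O[C@@H]2O[C@H](COC(c3ccccc3)(c3ccccc3)c3ccccc3)[C@@H](O)[C@H](O)[C@H]2O)[C@@H]2[C@@H](C)[C@@H](O)C[C@H]12`: 0.56 ug/mL
- compound 2 `COC(=O)C1=CO[C@@H](O[C@@H]2O[C@H](CO)[C@@H](OC(C)=O)[C@H](OC(C)=O)[C@H]2OC(C)=O)[C@@H]2[C@@H](C)[C@@H](OC(C)=O)C[C@H]12`: "not active" (no number reported)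
- compound 3 `CCC(=O)OC[C@H]1O[C@@H](O[C@@H]2OC=C(C(=O)OC)[C@H]3C[C@H](OC(C)=O)[C@H](C)[C@@H]23)[C@H](OC(C)=O)[C@@H](OC(C)=O)[C@@H]1OC(C)=O`: 2.85 ug/mL

Compound 3, at 2.85 ug/mL, holds the higher of the two numbers in this assay, and compound 1, at 0.56 ug/mL, lies lower by a gap beyond the scatter. Compound 2 gave no number, reported as "not active" (no number reported), so a numeric result is not assured in this series.

Next in line is compound 4 `CCCCCCCCCCCC(=O)OC[C@H]1O[C@@H](O[C@@H]2OC=C(C(=O)OC)[C@H]3C[C@H](OC(C)=O)[C@H](C)[C@@H]23)[C@H](OC(C)=O)[C@@H](OC(C)=O)[C@@H]1OC(C)=O`. Its difference from compound 3 is nonyl in place of hydrogen on a saturated chain carbon, two bonds along the chain from a carbonyl carbon.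

Among the measured compounds shown here, no two measured compounds differ in one place only, so the data show no precedent for the size or direction of this step. The working expectation in this assay is therefore no change beyond the scatter, with wide margins on either side. The estimated step is a 1.1-fold lower number from compound 3 to compound 4 (0.06 log units; within the scatter). For compound 4 the expected value is 2.5 ug/mL, within an estimated range of 0.7 ug/mL to 9 ug/mL.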

Compound 4, half-maximal inhibitory concentration: 0.42 ug/mL
Estimate against measurement, compound 4: 6.0-fold (0.77 log units) above, and the stated range ends above it.
By their numbers in this assay, from the lowest: compounds 4 and 1 (each within the scatter of the next); then compound 3.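

In this assay, among the compounds shown here, this position proves responsive: nonyl in place of hydrogen on a saturated chain carbon, two bonds along the chain from a carbonyl carbon, gives a 6.8-fold lower number from compound 3 to compound 4 (0.83 log units; beyond the scatter) and so supplies the only one-place step. The change goes toward stronger inhibition, so the added chain is tolerated here and no loss of the read-out follows from it. Nothing measured on these compounds bears on the reason for the step.

With only the shorter and the nonyl-extended chains shown, the compounds do not tell whether the number falls gradually with chain length, levels off or turns back with a longer chain such as hexadecyl. Also open, as far as these compounds go, is whether the step depends on the chain alone or would survive a terminal amine or carboxylic acid on it.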